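Aryl swap on the sulfur of the shared core

The compounds below may be only part of what the source reports. "The series", "measured", "known", "first", "only" and "open" are said of these compounds alone.

Measured so far:
compound 1 `Nc1cc(N)c2nc(-c3ccccc3)c(Oc3ccc(Cl)c(Cl)c3)nc2c1` — a functional assay on NCI/ADR-RES cells (Homo sapiens) for inhibition, read by sulforhodamine B assay, with a stated time of 48 h; on this read-out lower numbers stand for higher toxicity in this test and higher numbers for lower toxicity in this test: < 100000 nM (a limit, not a number)
compound 2 `COc1ccc(Sc2nc3cc(N)cc(N)c3nc2-c2ccccc2)cc1` — this assay : < 100000 nM (a limit, not a number)

Compound 2 stands only at a limit in this assay; (the limit of < 100000 nM in this assay, at which 2 of the 2 values shown sit). Within the data shown here, the one measured step, a step that the two limits leave unreadable from compound 1 to compound 2, is unreadable and gives no size. Compound 3 `Nc1cc(N)c2nc(-c3ccccc3)c(Sc3ccc(Cl)c(Cl)c3)nc2c1` differs from compound 2 by 3,4-dichlorophenyl in place of 4-methoxyphenyl on a sulfur. Since compound 1 already carries the 3,4-dichlorophenyl pattern at its limit, compound 3 is expected to sit within the limit as well, with an estimated value of 30000 nM, ranging from 5000 nM to 100000 nM. The expected step is a step that the limit leaves unreadable from compound 2 to compound 3, not readable beyond the scatter.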

Compound 3, concentration lethal to 50% of the cells: < 100000 nM
Compound 3: only a limit was reported (the forecaster's own chance of this, stated with the estimate: 60%); the middle value is on the limit's open side.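

No step between compound 1, compound 2 and compound 3 can be read in this assay, as each value is only a limit: the limit of < 100000 nM in this assay, at which 3 of the 3 values shown sit.

The compounds shown leave open whether (4-methoxyphenyl)sulfanyl, (3,4-dichlorophenyl)sulfanyl and 3,4-dichlorophenoxy differ at all on the shared core.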